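A Methoxy Group Enters the Phenyl Ring of Compound 3

The source may hold more compounds than are shown below. What is called first, only, known or untested is meant among the compounds shown, and "the series" means these compounds.

Three compounds share one core and differ only in a single substituent. Compound 1 `c1ccc(-c2nn(-c3ccccc3)cc2-c2nc3ccccc3[nH]2)cc1` gives 2710 nM in a functional assay on A549 cells (Homo sapiens) for antiproliferative activity, read by MTT assay, with a stated time of 48 h; a lower number here means a stronger inhibitor, a higher number a weaker inhibitor. Compound 2 `Clc1ccc2[nH]c(-c3cn(-c4ccccc4)nc3-c3ccccc3)nc2c1` gives 2370 nM in this assay, and compound 3 `Brc1ccc2[nH]c(-c3cn(-c4ccccc4)nc3-c3ccccc3)nc2c1` gives 1810 nM. Compound 3 has the lowest of the three numbers, but the steps of a 1.5-fold lower number from compound 1 to compound 3 (0.18 log units; within the scatter) and a 1.3-fold lower number from compound 2 to compound 3 (0.12 log units; within the scatter) both lie within the scatter, as does a 1.1-fold lower number from compound 1 to compound 2 (0.06 log units; within the scatter), so the three are not separated.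

Compound 4 `COc1ccc(-c2nn(-c3ccccc3)cc2-c2nc3cc(Br)ccc3[nH]2)cc1` differs from compound 3 by methoxy in place of hydrogen on an aromatic carbon. Going by the values given here, none of the measured steps touch this part of the core: all three concern the halogen on the other ring, and they were all within the scatter anyway. Among the compounds with values here, there is therefore no measured step that bears on the change, and no direction can be read from the data. The step of a 1.0-fold lower number from compound 3 to compound 4 (0.00 log units; within the scatter) is expected to stay within the scatter. Compound 4 is estimated at 1800 nM, with a range from 700 nM to 4500 nM.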

Compound 4, half-maximal inhibitory concentration: 6370 nM
The estimate for compound 4 lay 3.5-fold (0.55 log units) below the measured number; the whole stated range lies below it.
By their numbers in this assay, from the lowest: compounds 3, 2 and 1 (each within the scatter of the next); then compound 4.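

Going by these compounds alone, this is the first step that lies beyond the scatter: in this assay there is a 3.5-fold higher number from compound 3 to compound 4 (0.55 log units; beyond the scatter), with methoxy in place of hydrogen on an aromatic carbon, para to a large group. The steps among compound 1, compound 2 and compound 3 had separated nothing, whereas the change from phenyl to 4-methoxyphenyl shows that this position responds, modestly and towards a weaker inhibitor. No measurement shown here accounts for this shift.

On these data alone, it remains open whether the shift belongs to methoxy itself or would follow from other groups at this place, such as a fluoro, a hydroxyl or an amine. As far as these compounds go, it is also open whether the same change would move the number in the same way on compound 1 or compound 2.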